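The compounds below may be only part of what the source reports. "The series", "measured", "known", "first", "only" and "open" are said of these compounds alone.

Series notes. For the measured compounds named here, in a functional assay on NCI-H23 cells (Homo sapiens) for cytotoxicity, read by sulforhodamine B assay, with a stated time of 48 h, tested at 100 uM (a higher number here means a weaker effect of the compound at the concentration tested, a lower number a stronger effect), compound 3 `COc1ccc(C(=O)/C=C/c2cc(-c3cc(OC)c(OC)c(OC)c3)n[nH]2)cc1OC` gives -75%, the lowest of the three numbers measured so far. Compound 1 `COc1cc(-c2cc(/C=C/C(=O)c3ccc(N)cc3)[nH]n2)cc(OC)c1OC` gives -55% and compound 2 `COc1cc(-c2cc(/C=C/C(=O)c3ccc(Cl)c(Cl)c3)[nH]n2)cc(OC)c1OC` gives 5%; the steps of a number 20 percentage points lower from compound 1 to compound 3 (beyond the scatter) and a number 80 percentage points lower from compound 2 to compound 3 (beyond the scatter) are both beyond the scatter, as is a number 60 percentage points higher from compound 1 to compound 2 (beyond the scatter). Compound 4 `COc1ccc(C(=O)/C=C/c2cc(-c3cc(OC)c(OC)c(OC)c3)n[nH]2)cc1` differs from compound 3 by hydrogen in place of methoxy on an aromatic carbon. Going by the values given here, no measured step removes a single methoxy; all three exchange the whole aryl group on the carbonyl carbon, and each moved this assay beyond the scatter, so the aryl on that carbon matters. A smaller change there is expected to move this assay less, probably toward the number of compound 1. Compound 4 is therefore expected to give -60%, within -85% to -20%. The expected step is a number 15 percentage points higher from compound 3 to compound 4 (beyond the scatter).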

Compound 4, a percentage reported as activity, at one concentration (the size of the read-out at that concentration, not a potency): -23%
Beside the measured number, compound 4's estimate is 37 percentage points below it; the range from low to high includes it.
By their numbers in this assay, from the lowest: compound 3; then compound 1; then compound 4; then compound 2.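

Removing one methoxy is enough to move this assay: a number 52 percentage points higher from compound 3 to compound 4 (beyond the scatter) shows that a single group on this aromatic ring matters, not only exchange of the whole aryl. The 4-methoxyphenyl compound also stands apart from the other aryl groups, with a number 28 percentage points lower from compound 2 to compound 4 (beyond the scatter) and a number 32 percentage points higher from compound 1 to compound 4 (beyond the scatter) both printed as beyond the scatter. Nothing available explains the effect of this methoxy.

Open, as far as these compounds go, is whether hydroxy, fluorine or ethoxy in place of that methoxy would hold the number of compound 3 in this assay or fall toward that of compound 4.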